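This account rests on a few compounds, and the source may have more. Where it says the series, first, only, none or still open, it means among the compounds named here.

Going by the values given here, the series shares a 2-aminothiazole bearing a substituted benzylic carbon, and all three compounds measured so far were examined in an ADME assay on HepG2 2.2.15 cells (Homo sapiens) for cytotoxicity; on this read-out higher numbers stand for lower toxicity in this test and lower numbers for higher toxicity in this test. Compound 1, `O=C(CCCCC(=O)Nc1ncc(Cc2ccc(F)cc2)s1)Nc1ncc(Cc2ccc(F)cc2)s1`, was tested first in this regard and gave only a limit of the assay, > 50000 nM. Compound 2, `O=C(Nc1ncc(C(OCc2ccc(F)cc2F)c2ccccc2)s1)c1cccs1`, is recorded in this assay simply as "not toxic" (no number reported). Among the compounds with values here, compound 3, `CCCCC(CC)CNc1ncc(C(Oc2ccc3cc(Br)ccc3c2)c2ccc(Cl)cc2)s1`, is likewise recorded in this assay as "not toxic" (no number reported), so no single number stands for it; the one further value shown sits at the limit of > 50000 nM in this assay, at which 1 of the 3 values shown sits, and the remaining entry carries no number at all. Nothing among these three compounds points to measurable cytotoxicity.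

Compound 4, `O=C(Nc1ncc(C(Oc2ccc3cc(Br)ccc3c2)c2ccc(Cl)cc2)s1)c1ccc(Cl)nc1`, differs from compound 3 in one place: (6-chloropyridin-3-yl)carbonyl in place of 2-ethylhexyl on a nitrogen on an aromatic ring. Within the data shown here, no measured pair in the set shares this change, so there is no step to lean on. Given that every value shown so far either sits at the limit or is recorded without a number, the expectation for this assay is a step of no size beyond the scatter, in no particular direction. For compound 4 the half-maximal cytotoxic concentration is therefore estimated at 50000 nM, within a range from 20000 nM to 100000 nM, most likely to be reported again only as a limit.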

Compound 4, half-maximal cytotoxic concentration: "not toxic" (no number reported)
The entry for compound 4 holds no number, and the estimate cannot be compared.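

Compound 3 and compound 4 are both recorded in this assay as "not toxic" without a number, so no step can be read between them. The compounds shown leave open at what concentration any of them would become cytotoxic, and the only figure on record is a limit: the limit of > 50000 nM in this assay, at which 1 of the 4 values shown sits.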